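The compounds below may be only part of what the source reports. "The series", "measured", "known", "first", "only" and "open" are said of these compounds alone.

Measured in a functional assay on MCF7 cells (Homo sapiens) for cytotoxicity, read by MTT assay, with a stated time of 48 h; a lower number here means a stronger inhibitor, a higher number a weaker inhibitor:
- compound 1 `C/C(=N\NC(=S)Nc1cccc(F)c1)c1ccccn1`: 9 nM
- compound 2 `CC(=NNC(=S)Nc1cccc(F)c1)c1ccccn1`: 9 nM
- compound 3 `C/C(=N/NC(=S)Nc1cccc([N+](=O)[O-])c1)c1ccccn1`: 38 nM

In this assay, compound 2 at 9 nM stands level with compound 1, while compound 3 lies higher at 38 nM, beyond the scatter. The change to compound 4 `CC(=NNC(=S)Nc1ccccc1)c1ccccn1` is hydrogen in place of fluoro on an aromatic carbon. Going by the values given here, the only measured step, no change at the digits printed from compound 1 to compound 2 (within the scatter), concerns the fact that one of compounds 1 and 2 is drawn with a defined configuration and the other without, at the place where they differ and leaves the fluoro group untouched, so no measured step bears directly on this change. With no direction shown, the expected step is small, a 1.3-fold higher number from compound 2 to compound 4 (0.12 log units; within the scatter), within the scatter. For compound 4 the estimated value is 12 nM, with an expected range of 3 nM to 50 nM.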

Compound 4, half-maximal inhibitory concentration: 0.18 nM
Beside the measured number, compound 4's estimate is 67-fold (1.82 log units) above it; measured number outside the range, below it.
By their numbers in this assay, from the lowest: compound 4; then compounds 1 and 2 (each within the scatter of the next); then compound 3.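

In this assay this place on the aromatic ring proves highly sensitive, since replacing fluoro with hydrogen, a change of a single heavy atom, moves the number sharply (a 50-fold lower number from compound 2 to compound 4 (1.70 log units; beyond the scatter)). Going by these compounds alone, the earlier step left the fluoro group untouched, so only this pair shows how much the group matters here. Nothing available explains the size of this step.

Still open, going by these compounds, is where other groups at this place, such as chloro, methoxy or an amine, would fall relative to hydrogen and fluoro. On these data alone, whether the same step would hold on a different core also remains unknown.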